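The source may hold more compounds than are shown below. What is called first, only, known or untested is meant among the compounds shown, and "the series" means these compounds.

Measured so far:
compound 1 `COc1ccc(OC)c(C(=O)/C=C/c2ccc(C(=O)O)cc2)c1` — a functional assay on PC-3 cells (Homo sapiens) for cytotoxicity, read by MTT assay, with a stated time of 72 h; on this read-out lower numbers stand for stronger inhibition and higher numbers for weaker inhibition: 7240 nM
compound 2 `COC(=O)c1ccc(/C=C/C(=O)c2cc(OC)ccc2OC)cc1` — this assay: 4850 nM

Among the compounds with values here, compound 2 holds the lower of the two numbers, with compound 1 as its only neighbour; that step, a 1.5-fold lower number from compound 1 to compound 2 (0.17 log units; within the scatter), stays within the scatter. Compound 3 `COc1ccc(OC)c(C(=O)/C=C/c2ccc(C(=O)OC(C)C)cc2)c1` is the next change at the same place: isopropyl in place of methyl on an oxygen next to a carbonyl group. Within the data shown here, the one step that bears on it, methyl for hydrogen on that oxygen, was small, so for compound 3 in this assay no step beyond the scatter is expected, a 1.1-fold lower number from compound 2 to compound 3 (0.03 log units; within the scatter). Compound 3 is therefore estimated at 4500 nM, with a range of 2000 nM to 10000 nM.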

Compound 3, half-maximal inhibitory concentration: 6740 nM
For compound 3 the middle estimate is 1.5-fold (0.18 log units) below the measured one; low and high end bracket the measured number.
By their numbers in this assay, from the lowest: compounds 2, 3 and 1 (each within the scatter of the next).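

In this assay, isopropyl in place of methyl on this oxygen gives a 1.4-fold higher number from compound 2 to compound 3 (0.14 log units; within the scatter) and isopropyl in place of hydrogen gives a 1.1-fold lower number from compound 1 to compound 3 (0.03 log units; within the scatter), so the larger group adds no readable step to the earlier one. Hydrogen, methyl and isopropyl at this position thus stay within the scatter of one another. No measurement at hand offers a cause for these numbers.

On these data alone, whether a longer chain on this oxygen, or an amide in place of the oxygen-linked groups, would give a step beyond the scatter stays open.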